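Working notes: ring-nitrogen substituent change toward compound 3

The compounds below may be only part of what the source reports. "The series", "measured", "known", "first", "only" and "open" are said of these compounds alone.

Measured compounds:
compound 1 `N#Cc1ccccc1CN1CCc2c(sc(NC(=O)c3ccccc3Cl)c2C(N)=O)C1`: 9500 nM
compound 2 `Cc1ccc(C(=O)Nc2sc3c(c2C(N)=O)CCN(Cc2ccc(Cl)cc2Cl)C3)cc1`: 25500 nM

In a functional assay on MKN-74 cells (Homo sapiens) for antiproliferative activity, with a stated time of 24 h (on this read-out lower numbers stand for stronger inhibition and higher numbers for weaker inhibition), compound 1 gives 9500 nM, the lowest of the two numbers; compound 2 gives 25500 nM, a higher number beyond the scatter. Compound 3 `NC(=O)c1c(NC(=O)c2ccccc2Cl)sc2c1CCN(C(=O)Nc1c(Cl)cccc1Cl)C2` is not yet measured. It differs from compound 1 as follows: (2,6-dichlorophenyl)carbamoyl in place of 2-cyanobenzyl on an amine nitrogen in a ring. Within the data shown here, no measured pair shows a change of this kind, so nothing fixes the direction. A modest weakening beyond the scatter is expected in this assay. The expected step is a 1.9-fold higher number from compound 1 to compound 3 (0.28 log units; within the scatter). Compound 3 is estimated at 18000 nM, with a range from 6000 nM to 55000 nM.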

Compound 3, half-maximal inhibitory concentration: 24400 nM
Estimate against measurement, compound 3: 1.4-fold (0.13 log units) below; the range from low to high includes it.
By their numbers in this assay, from the lowest: compound 1; then compounds 3 and 2 (each within the scatter of the next).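

Among these compounds, on the amine nitrogen in a ring, this assay now gives a first reading of a single-place change: (2,6-dichlorophenyl)carbamoyl in place of 2-cyanobenzyl brings a 2.6-fold higher number from compound 1 to compound 3 (0.41 log units; beyond the scatter), a modest weakening. This position therefore accepts a carbamoyl link, with the loss staying modest. Nothing available bears on the reason for this step.

As far as these compounds go, whether the step follows the carbamoyl link or the two chlorines stays open, as the two change together here. Also open, from the compounds shown here alone, is how an unsubstituted benzyl or an acetyl group on this nitrogen would read.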